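Nitro in Place of Hydrogen on Compound 2

The compounds below may be only part of what the source reports. "The series", "measured", "known", "first", "only" and "open" are said of these compounds alone.

In a functional assay on DU-145 cells (Homo sapiens) for inhibition, read by trypan blue exclusion, with a stated time of 96 h (a higher number here means a weaker inhibitor of growth, a lower number a stronger inhibitor of growth), compound 2 (`O=C(O)c1ccc(C(=O)/C(=C\c2ccc(Br)cc2)SCc2ccc(F)cc2)cc1`) gives > 100000 nM as its reading, and this is a limit and not a number. Compound 3 (`CCOc1cc(/C=C(\Cc2ccc(Cl)cc2Cl)C(=O)c2ccc(Cl)cc2)ccc1O`) gives 10000 nM in this assay as a measured value. Compound 4 (`O=C(O)c1ccc(C(=O)/C(=C\c2ccc(Br)c([N+](=O)[O-])c2)SCc2ccc(F)cc2)cc1`) has nitro in place of hydrogen on an aromatic carbon of compound 2 (nitro in place of hydrogen on an aromatic carbon), ortho to a bromo group, which turns 4-bromophenyl into 4-bromo-3-nitrophenyl. The expectation rests on compound 1 (`O=C(O)c1ccc(C(=O)/C(=C\c2ccc(Br)c([N+](=O)[O-])c2)SCc2ccc(Cl)cc2)cc1`), which also carries 4-bromo-3-nitrophenyl and gives < 1000 nM as a limit. The expected change is a large one toward stronger inhibition of growth, well beyond the scatter, with an estimated step of an at least 110-fold lower number from compound 2 to compound 4 (2.04 log units; beyond the scatter) in this assay. Compound 4 is estimated at 900 nM (expected range 200 nM to 5000 nM).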

Compound 4, concentration for 50% growth inhibition: 1000 nM
Estimate against measurement, compound 4: 1.1-fold (0.05 log units) below; the range from low to high includes it.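

In this assay, nitro in place of hydrogen on an aromatic carbon, ortho to a bromo group, gives an at least 100-fold lower number from compound 2 to compound 4 (2.00 log units; beyond the scatter). On these data alone, the full size of that step stays open because compound 2 stands at a limit: the limit of > 100000 nM in this assay, at which 1 of the 4 values shown sits. Fluoro in place of chloro on an aromatic carbon gives a number no lower from compound 1 to compound 4 (the limit leaves the size open). The size of this step cannot be read because compound 1 stands at a limit: the limit of < 1000 nM in this assay, at which 1 of the 4 values shown sits.

The compounds shown leave open whether an amine or a nitrile in the same place would give a step of like size. They also leave open whether nitro would do so without the bromo group.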